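The source may report more compounds than this note shows. Statements on the series, on what has been measured and on what is new or still open speak of the compounds shown alone.

Measured so far in an assay (Cricetulus griseus) for inhibition of aldehyde dehydrogenase, mitochondrial (Homo sapiens); on this read-out lower numbers stand for stronger inhibition and higher numbers for weaker inhibition:
compound 1 `O=c1c(-c2ccc(O)cc2)coc2cc(OCCCCCCCCCO)ccc12` gives 700 nM
compound 2 `O=C(O)CCCCCOc1ccc2c(=O)cc(-c3ccc(O)cc3)oc2c1` gives 3500 nM
compound 3 `O=C(O)CCCCCCCCCOc1ccc2c(=O)c(-c3ccc(O)cc3)coc2c1` gives 50 nM

Within this set compound 1 stands second highest of the three numbers; compound 2 is nearest, compound 3 furthest, with a 14-fold lower number from compound 1 to compound 3 (1.15 log units; beyond the scatter) the only single-place step available, and a large one.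

Compound 4 `CCOc1ccc2c(=O)c(-c3ccc(O)cc3)coc2c1` has not yet been measured. Against compound 1 the change is hydrogen in place of 7-hydroxyheptyl on a saturated chain carbon, two bonds along the chain from an oxygen on an aromatic ring.

Among the compounds with values here, no measured step bears directly on this change: the one known step concerns the chain terminus, not the loss of most of the chain. Compounds 2 and 3 differ in more than one place and show only that the shorter-chain acid of compound 2 gives the higher number. Since the step from compound 1 to compound 3 is large, the terminus appears to matter, and removing it along with the chain is expected to weaken binding.

For compound 4 in this assay the estimate is 3000 nM with range 800 nM to 12000 nM, an expected step of a 4.3-fold higher number from compound 1 to compound 4 (0.63 log units; beyond the scatter).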

Compound 4, half-maximal inhibitory concentration: 80 nM
Compound 4: the middle estimate sits 38-fold (1.57 log units) above what was measured; the whole stated range lies above it.
By their numbers in this assay, from the lowest: compounds 3 and 4 (each within the scatter of the next); then compound 1; then compound 2.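

In this assay, the long chain is not required at this position: replacing 7-hydroxyheptyl with hydrogen gives an 8.8-fold lower number from compound 1 to compound 4 (0.94 log units; beyond the scatter) and is a gain rather than the expected loss. Replacing 7-carboxyheptyl with hydrogen gives a 1.6-fold higher number from compound 3 to compound 4 (0.20 log units; within the scatter), so the carboxy-ended chain and the much shorter group cannot be told apart here. Within the data shown here, the large step between compound 1 and compound 3 therefore marks the hydroxy-ended chain as the one that raises the number, rather than showing a need for the carboxy end; nothing available explains this result.

Going by these compounds, it remains open how the number changes with intermediate chain lengths on this core, whether ending in a hydroxy group or a carboxylic acid. An amine at the chain end is also untested in the compounds shown.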